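Fluoro in Place of Hydroxy on a Low-Toxicity Core

The source may report more compounds than this note shows. Statements on the series, on what has been measured and on what is new or still open speak of the compounds shown alone.

Among the measured compounds shown here, compound 1 `COc1ccc(OC)c([C@H]2CC(C)(O)[C@@H]3CC[C@@H](C)C[C@H]3O2)c1` is the only compound here with a definite number: in an ADME assay on MDCK cells (Canis lupus familiaris) for cytotoxicity, read by MTT assay, with a stated time of 48 h (on this read-out lower numbers stand for higher toxicity in this test and higher numbers for lower toxicity in this test), compound 1 gives 512000 nM. Compound 2 `COc1cc(OC)c([C@H]2CC(C)(O)[C@@H]3CC[C@@H](C)C[C@H]3O2)cc1OC` reaches only > 857000 nM, a limit of the assay rather than a number; it sits at the limit of > 857000 nM in this assay, at which 1 of the 2 values shown sits. For the measured compounds named here, the one measured step, an at least 1.6-fold higher number from compound 1 to compound 2 (0.22 log units; that floor lies within the scatter), concerns a methoxy on an aromatic carbon.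

Compound 3 `COc1ccc(OC)c([C@H]2CC(C)(F)[C@@H]3CC[C@@H](C)C[C@H]3O2)c1` differs from compound 1 by fluoro in place of hydroxy on a saturated ring carbon. Going by the values given here, no measured step touches this exchange or this place, so none bears on it. I therefore expect no step beyond the scatter in this assay and estimate compound 3 at 512000 nM, within 250000 nM to 1000000 nM. The expected step, no change at the digits printed from compound 1 to compound 3 (within the scatter), lies within the scatter.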

Compound 3, half-maximal cytotoxic concentration: 37000 nM
Compound 3: the middle estimate sits 14-fold (1.14 log units) above what was measured; measured number outside the range, below it.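

In this assay, fluoro in place of hydroxy on this saturated ring carbon gives a 14-fold lower number from compound 1 to compound 3 (1.14 log units; beyond the scatter), which here means higher toxicity in this test. Among the compounds shown here, this shows that a single exchange at this position can move the read-out well beyond the scatter, something the earlier compounds did not show. Nothing shown here explains why this exchange has so large an effect.

From the compounds shown here alone, whether the change comes from fluoro arriving or from hydroxy leaving stays open. An amine or a plain hydrogen on this carbon would help separate the two.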